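The source may report more compounds than this note shows. Statements on the series, on what has been measured and on what is new or still open speak of the compounds shown alone.

Of the compounds shown here, three built on one shared core have been tested in a functional assay on NCI-H661 cells (Homo sapiens) for cytotoxicity, read by WST assay, with a stated time of 72 h; on this read-out higher numbers stand for weaker inhibition and lower numbers for stronger inhibition. Compound 1 `COc1cc2c(Nc3nc4ccc(C(=O)Nc5c(C)cccc5C)cc4s3)ncnc2cc1OCCCN1CCCC1` gives only a limit in this assay, > 100000 nM. Compound 2 `COc1cc2c(Nc3nc4ccc(C(=O)Nc5c(C)cccc5C)cc4s3)ncnc2cc1OCCCN1CCCCC1C` gives 84400 nM in this assay, and compound 3 `COc1cc2c(Nc3nc4ccc(C(=O)Nc5c(C)cccc5C)cc4s3)ncnc2cc1OCCCN1CCC(C)CC1` gives 72300 nM. The steps of an at least 1.1-fold lower number from compound 1 to compound 2 (0.07 log units; that floor lies within the scatter) and an at least 1.3-fold lower number from compound 1 to compound 3 (0.14 log units; that floor lies within the scatter) both start from the limit of compound 1 (the limit of > 100000 nM in this assay, at which 1 of the 3 values shown sits), and the step of a 1.2-fold lower number from compound 2 to compound 3 (0.07 log units; within the scatter) is likewise small. Each of these three steps exchanges the ring on the saturated chain carbon three bonds along the chain from an oxygen on an aromatic ring. Compound 4 `COc1cc2c(Nc3nc4ccc(C(=O)Nc5c(C)cccc5Cl)cc4s3)ncnc2cc1OCCCN1CCCC1` differs from compound 1 elsewhere: chloro in place of methyl on an aromatic carbon, within the (2,6-dimethylphenyl)carbamoyl group. Going by the values given here, no measured step touches that part of the molecule, so none bears directly on this change, and all three measured compounds remain weak in this assay. The step to compound 4 is expected to be small, an at least 1.0-fold lower number from compound 1 to compound 4 (0.02 log units; that floor lies within the scatter), and to lie within the scatter. The estimate for compound 4 in this assay is 95000 nM, within a range from 45000 nM to 200000 nM.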

Compound 4, half-maximal inhibitory concentration: 45500 nM
The estimate for compound 4 lay 2.1-fold (0.32 log units) above the measured number, and the stated range covers the measured number.
By their numbers in this assay, from the lowest: compounds 4, 3 and 2 (each within the scatter of the next). At a limit, above all of these: compound 1.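

In this assay, exchanging methyl for chloro in the 2,6-dimethylphenyl group gives an at least 2.1-fold lower number from compound 1 to compound 4 (0.34 log units; beyond the scatter). This is the first step shown at this aromatic position, and unlike the steps among compounds at the ring on the chain, it is printed as beyond the scatter, so a change of one heavy atom here is enough to shift the number. The size of this step is only a floor, and the true step may be larger: the limit of > 100000 nM in this assay, at which 1 of the 4 values shown sits.

Even so, compound 4 still gives 45500 nM, and the compounds shown do not tell whether fluoro, methoxy or a nitrile in the same place would act like chloro, or what a 2,6-dichlorophenyl group would give. They also leave open whether the step from methyl to chloro would hold with 4-methylpiperidin-1-yl on the chain in place of pyrrolidin-1-yl.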